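The source may hold more compounds than are shown below. What is called first, only, known or untested is meant among the compounds shown, and "the series" means these compounds.

Three compounds share one core and differ mainly in the aryl group carried on the amide-bound chain carbon. In a functional assay on NCI-H3122 cells (Homo sapiens) for antiproliferative activity, read by MTT assay, with a stated time of 48 h (on this read-out higher numbers stand for weaker inhibition and lower numbers for stronger inhibition), compound 1 `COc1ccc(CNC(=O)c2cccc(C(C)Oc3ccnc(Nc4cnn(C)c4)c3)c2)cc1OC` gives 38500 nM, compound 2 `Cc1ccc(CNC(=O)c2cccc(C(C)Oc3ccnc(Nc4cnn(C5CCN(C)CC5)c4)c3)c2)cc1` gives 8900 nM, and compound 3 `CC(Oc1ccnc(Nc2cnn(C)c2)c1)c1cccc(C(=O)NCc2cc(F)cc(F)c2)c1` gives 7600 nM, the lowest of the three numbers, with compound 2 within the scatter of it and compound 1 beyond it. The step of a 5.1-fold lower number from compound 1 to compound 3 (0.70 log units; beyond the scatter) shows that this aryl position matters. Compound 4 `Cc1ccc(CNC(=O)c2cccc(C(C)Oc3ccnc(Nc4cnn(C)c4)c3)c2)cc1` carries the change (4-methylphenyl in place of 3,5-difluorophenyl on a saturated chain carbon bound to an amide-type nitrogen). Compound 2 also bears a 4-methylphenyl here and its number sits close to that of compound 3, so no step beyond the scatter is expected for compound 4, with a 1.3-fold higher number from compound 3 to compound 4 (0.12 log units; within the scatter) as the estimated step. Compound 4 is therefore expected at 10000 nM, within 4000 nM to 30000 nM.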

Compound 4, half-maximal inhibitory concentration: 7700 nM
Estimate against measurement, compound 4: 1.3-fold (0.11 log units) above, within the range that was stated.
By their numbers in this assay, from the lowest: compounds 3, 4 and 2 (each within the scatter of the next); then compound 1.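

In this assay, 3,5-difluorophenyl and 4-methylphenyl on the chain carbon cannot be told apart, at a 1.0-fold higher number from compound 3 to compound 4 (0.01 log units; within the scatter), while replacing 3,4-dimethoxyphenyl with 4-methylphenyl gives a step beyond the scatter, a 5.0-fold lower number from compound 1 to compound 4 (0.70 log units; beyond the scatter). On the aromatic nitrogen, methyl and 1-methylpiperidin-4-yl also cannot be told apart, at a 1.2-fold lower number from compound 2 to compound 4 (0.06 log units; within the scatter). Nothing given here explains these results. As far as these compounds go, it remains open how an amine or a carboxylic acid on the aryl ring, or a longer chain in place of the benzyl group, would read in this assay.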